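Two Dimethoxyphenyl Isomers Compared for Cell Growth Inhibition

This account rests on a few compounds, and the source may have more. Where it says the series, first, only, none or still open, it means among the compounds named here.

Measured so far:
compound 1 `COc1ccc(C2OC(c3cc(OC)c(OC)c(OC)c3)=NN2C(C)=O)c(OC)c1`: 92%
compound 2 `COc1cccc(/C=N/NC(=O)c2cc(OC)c(OC)c(OC)c2)c1OC`: 67%

In a functional assay on PC-3 cells (Homo sapiens) for antiproliferative activity, read by MTT assay, tested at 5 uM (a higher number here means a stronger effect of the compound at the concentration tested, a lower number a weaker effect), compound 1 gives 92%, the higher of the two numbers. Compound 2 gives 67%, and that gap lies beyond the usual scatter. Compound 3 `COc1ccc(OC)c(C2OC(c3cc(OC)c(OC)c(OC)c3)=NN2C(C)=O)c1` differs from compound 1 by 2,5-dimethoxyphenyl in place of 2,4-dimethoxyphenyl on a saturated ring carbon. Among the measured compounds shown here, no measured pair shows this change, so its size is unknown. The step of a number 12 percentage points lower from compound 1 to compound 3 (beyond the scatter) is expected to be a small loss or none beyond the scatter. The estimate for compound 3 is 80%, with a range from 55% to 95%.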

Compound 3, a percentage reported as inhibition, at one concentration (the size of the read-out at that concentration, not a potency): 43.2%
Estimate against measurement, compound 3: 36.8 percentage points above; measured number below the stated range.
By their numbers in this assay, from the lowest: compound 3; then compound 2; then compound 1.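

Changing 2,4-dimethoxyphenyl to 2,5-dimethoxyphenyl on a saturated ring carbon gives a number 48.8 percentage points lower from compound 1 to compound 3 (beyond the scatter) in this assay and so shows that this position is far from indifferent to the change. The two compounds hold the same atoms, joined differently, so the arrangement of the methoxy groups on this phenyl ring alone is enough to produce a large loss. No measurement at hand explains that loss.

From the compounds shown here alone, whether a single methoxy group on this ring would hold the higher number stays open. So does the effect of an amine or a hydroxy group in place of a methoxy group.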